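Cytotoxicity notes: trimming the side chain of compound 1

A few compounds are considered here, and "the series" means these few. Any claim that something is new, unique, unknown or untested is made for them only; others in the source may bear on it.

Measured so far:
compound 1 `CC(C)CC1(Cc2ccccc2)OS(=O)(=O)C=C1OCc1ccccc1` — >= 80000 nM
compound 2 `CCC1(Cc2ccccc2)OS(=O)(=O)C=C1OCc1ccc(Cl)c(Cl)c1` — >= 20000 nM

In an ADME assay on HEL cells (Homo sapiens) for cytotoxicity, with a stated time of 3 days (on this read-out lower numbers stand for higher toxicity in this test and higher numbers for lower toxicity in this test), compound 1 gives >= 80000 nM, which is a limit of the assay and not a number. Compound 1 therefore stands at the limit of >= 80000 nM in this assay, at which 1 of the 2 values shown sits. Compound 2 gives >= 20000 nM in this assay, again only a limit. Compound 2 stands at the limit of >= 20000 nM in this assay, at which 1 of the 2 values shown sits. Going by the values given here, no measured pair covers a single change, so no step size is known.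

Compound 3 `CC1(Cc2ccccc2)OS(=O)(=O)C=C1OCc1ccccc1` differs from compound 1 by hydrogen in place of isopropyl on a saturated chain carbon bound to a saturated ring carbon. In this assay no step beyond the usual scatter is expected for this change. Compound 3 is expected at 80000 nM, within 30000 nM to 200000 nM, most likely reported again as a limit. The expected step is a number no higher from compound 1 to compound 3 (the limit leaves the size open).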

Compound 3, minimum cytotoxic concentration: > 400000 nM
Compound 3 gave a limit, no number; the forecaster's own chance of this, stated with the estimate: 85%; middle value at least 5.0-fold (0.69 log units) away from the limit.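

Compound 1 and compound 3 both give only limits, so no step can be read between them. The compounds shown leave open the size of any effect of hydrogen in place of isopropyl on minimum cytotoxic concentration.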